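Swapping trifluoromethyl for amino on a hydrazone benzamide series

The source may report more compounds than this note shows. Statements on the series, on what has been measured and on what is new or still open speak of the compounds shown alone.

Measured so far:
compound 1 `Nc1ccc(C(=O)NN=C(c2ccccn2)c2ccccn2)cc1`, 7640 nM
compound 2 `O=C(NN=C(c1ccccn1)c1ccccn1)c1ccc(C(F)(F)F)cc1`, 240 nM
compound 3 `O=C(N/N=C/c1ccccn1)c1ccc(C(F)(F)F)cc1`, 22400 nM

The assay is an ADME assay on cells (Homo sapiens) for antiproliferative activity, read by MTT assay; a higher number here means a weaker inhibitor, a lower number a stronger inhibitor. Compound 2 gives the lowest number, compound 3 the highest, and compound 1 lies between them. Compound 1 and compound 2 differ in one place: amino in place of trifluoromethyl on an aromatic carbon. That change produced a 32-fold higher number from compound 2 to compound 1 (1.50 log units; beyond the scatter).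

Compound 4 `Nc1ccc(C(=O)N/N=C/c2ccccn2)cc1` has not yet been measured. It is related to compound 3 exactly as compound 1 is to compound 2: amino in place of trifluoromethyl on an aromatic carbon. The place lines of the two changes read the same word for word, so this is the same change made on a different core. How the core of compound 3 differs from the core of compound 2 is not broken down here.

Since the same change once raised the number in a large step, a step of similar size is expected from compound 3 to compound 4, that is an 18-fold higher number from compound 3 to compound 4 (1.25 log units; beyond the scatter), because compound 3 already starts from 22400 nM. The estimate for compound 4 is therefore 400000 nM, with a range from 80000 nM to 2000000 nM, and a real chance that only a limit is reported.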

Compound 4, half-maximal inhibitory concentration: > 80000 nM
Compound 4 gave a limit, no number; the forecaster's own chance of this, stated with the estimate: 55%; the middle value lies beyond the limit too.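

In this assay, putting amino in place of trifluoromethyl raises the number on the second core as well, with an at least 3.5-fold higher number from compound 3 to compound 4 (0.55 log units; beyond the scatter), so on these two cores the change goes the same way and the step is beyond the usual scatter. Compound 4 gave only a limit, > 80000 nM, and not an exact number, so this step has a floor but no known size. The result therefore does not show that the change carries over with the same size, and the comparison with the earlier step remains undecided: the same change on two cores in this assay, a 32-fold higher number (1.50 log units; beyond the scatter) from compound 2 to compound 1 and an at least 3.5-fold higher number (0.55 log units; beyond the scatter) from compound 3 to compound 4; the limit leaves it open whether they differ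

The compounds shown have only trifluoromethyl or amino at this place, which leaves open where another group there, such as a chlorine atom, a methoxy group or a nitrile, would fall on either core. They also leave open whether the change would go the same way on any core beyond these two.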